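Methylsulfonyl on the Urea Phenyl Ring of Compound 1

The compounds below may be only part of what the source reports. "The series", "measured", "known", "first", "only" and "open" are said of these compounds alone.

Compound 1 `O=C(Nc1ccccc1)Nc1cccc(CNc2nccnc2Cl)c1` carries a plain phenyl on an amide-type nitrogen of the shared core. In a functional assay on HepG2 cells (Homo sapiens) for antiproliferative activity, read by MTT assay, with a stated time of 48 h (a higher number here means a weaker inhibitor, a lower number a stronger inhibitor), compound 1 gives 15600 nM, the highest of the two numbers recorded. Compound 3 `O=C(Nc1cccc(CNc2nccnc2Cl)c1)Nc1ccc(Cl)c(Cl)c1` gives 6170 nM, so a 2.5-fold lower number from compound 1 to compound 3 (0.40 log units; beyond the scatter). For compound 2 `O=C(Nc1cccc(CNc2nccnc2Cl)c1)NC1CCCCC1` the assay reports only a limit, > 40000 nM, (the limit of > 40000 nM in this assay, at which 1 of the 3 values shown sits). Here an at least 2.5-fold higher number from compound 1 to compound 2 (0.40 log units; beyond the scatter). Compound 4 `CS(=O)(=O)c1ccc(NC(=O)Nc2cccc(CNc3nccnc3Cl)c2)cc1` differs from compound 1 in one place: methylsulfonyl in place of hydrogen on an aromatic carbon. Compound 3 shows that adding groups to this phenyl ring can lower the number, yet methylsulfonyl is a different kind of group, so only a small change is expected, a 1.4-fold lower number from compound 1 to compound 4 (0.15 log units; within the scatter). Compound 4 is therefore estimated at 11000 nM, within 4500 nM to 30000 nM.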

Compound 4, half-maximal inhibitory concentration: 15100 nM
Compound 4: the middle estimate sits 1.4-fold (0.14 log units) below what was measured, and the stated range covers the measured number.
By their numbers in this assay, from the lowest: compound 3; then compounds 4 and 1 (each within the scatter of the next). At a limit, above all of these: compound 2.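

In this assay, methylsulfonyl on this aromatic carbon, para to a large group, gives a 1.0-fold lower number from compound 1 to compound 4 (0.01 log units; within the scatter), so adding 4 heavy atoms here leaves the number where it was. Substitution on this phenyl ring therefore does not always lower the number, although 3,4-dichlorophenyl gives a 2.5-fold lower number from compound 1 to compound 3 (0.40 log units; beyond the scatter). Nothing measured here explains why methylsulfonyl leaves the number unchanged. The compounds shown leave open how an amine, a carboxylic acid or a single chlorine on this same carbon would behave.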